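Butoxy for benzyl on the urea-linked aryl ring

A few compounds are considered here, and "the series" means these few. Any claim that something is new, unique, unknown or untested is made for them only; others in the source may bear on it.

In a functional assay on OVCAR-4 cells (Homo sapiens) for inhibition, read by sulforhodamine B assay, with a stated time of 48 h (a higher number here means a weaker inhibitor of growth, a lower number a stronger inhibitor of growth), compound 2 `Nc1nn(C(=O)Nc2ccc(Cc3ccccc3)cc2)c2ccccc12` gives 10700 nM, the lowest of the two numbers recorded. Its nearest neighbour is compound 1 `O=C(Nc1ccccc1OC(F)(F)F)Nc1n[nH]c2ccccc12`, which in this assay gives 37700 nM, a gap beyond the scatter. Compound 3 `COc1ccc(NC(=O)Nc2n[nH]c3ccccc23)cc1` in this assay gives only a limit, > 100000 nM, and no number. Compound 4 `CCCCOc1ccc(NC(=O)n2nc(N)c3ccccc32)cc1` is not yet measured; it differs from compound 2 by butoxy in place of benzyl on an aromatic carbon. Among the compounds with values here, no measured pair shows this change. An alkoxy group stands on the corresponding ring of compound 3, and the limit of > 100000 nM in this assay, at which 1 of the 3 values shown sits, suggests the exchange may weaken growth inhibition. Compound 4 is expected to give 40000 nM in this assay, between 10000 nM and 150000 nM. The expected step from compound 2 to compound 4 is a 3.7-fold higher number from compound 2 to compound 4 (0.57 log units; beyond the scatter), beyond the scatter.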

Compound 4, concentration for 50% growth inhibition: 30700 nM
Compound 4: middle estimate off by 1.3-fold (0.11 log units), on the high side; measured number inside the range.
By their numbers in this assay, from the lowest: compound 2; then compounds 4 and 1 (each within the scatter of the next). At a limit, above all of these: compound 3.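

In this assay, butoxy in place of benzyl on this aromatic carbon, para to a large group, gives a 2.9-fold higher number from compound 2 to compound 4 (0.46 log units; beyond the scatter). The position therefore accepts a chain with no ring at some cost in growth inhibition, and compound 4 still gives a number rather than a limit. Nothing measured here accounts for the step. As far as these compounds go, whether the step follows the loss of the benzyl ring or the arrival of the butoxy oxygen stays open. A pentyl chain or a phenoxy group at this position would help separate the two.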